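Pyrazole Urea Series: Cyano for Methyl on the Pyrazole

This account rests on a few compounds, and the source may have more. Where it says the series, first, only, none or still open, it means among the compounds named here.

Measured so far:
compound 1 `O=C(NCc1ccc(OCc2ccccc2)cc1)n1cccn1`: 800 nM
compound 2 `Cc1cnn(C(=O)N(C)CCN(C)Cc2ccc(OCc3ccccc3)cc2)c1`: 8700 nM

In an assay on membranes from brain for binding affinity to Fatty-acid amide hydrolase 1 (Mus musculus), read by fluorescence, with stated times of 1 h and 30 min (a lower number here means a stronger inhibitor, a higher number a weaker inhibitor), compound 1 gives 800 nM. In this assay compound 2 gives 8700 nM, the higher of the two numbers, and the gap to compound 1 is beyond the scatter. The two compounds differ in more than one place, so their values are compared only as they stand, without a single step between them.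

Compound 3 `CN(CCN(C)C(=O)n1cc(C#N)cn1)Cc1ccc(OCc2ccccc2)cc1` is compound 2 with one change: cyano in place of methyl on an aromatic carbon. Going by the values given here, no measured pair shows this change, so the size of the step is uncertain. A moderate move toward a lower number in this assay is expected, beyond the scatter but not large, and the expected step from compound 2 to compound 3 is a 2.9-fold lower number from compound 2 to compound 3 (0.46 log units; beyond the scatter). For compound 3 the estimated value in this assay is 3000 nM, with a range from 800 nM to 10000 nM.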

Compound 3, half-maximal inhibitory concentration: 120 nM
For compound 3 the middle estimate is 25-fold (1.40 log units) above the measured one, and the stated range ends above it.
By their numbers in this assay, from the lowest: compound 3; then compound 1; then compound 2.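

In this assay, going by these compounds alone, the change from 4-methyl-1H-pyrazol-1-yl to 4-cyano-1H-pyrazol-1-yl gives a 73-fold lower number from compound 2 to compound 3 (1.86 log units; beyond the scatter) as the first single-place step, and a large one. This aromatic carbon of the five-membered ring is thus a place where the choice of group strongly moves the read-out, which compound 1 and compound 2 could not show, as they differ in more than one place. Nothing available accounts for the size of this step.

Still open, going by these compounds, is whether the step is specific to the nitrile or would also appear with another group on the same carbon, such as a carboxylic acid, a primary amide or a chlorine. Also open, on these data alone, is whether cyano gives a similar step on the core of compound 1.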